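This account rests on a few compounds, and the source may have more. Where it says the series, first, only, none or still open, it means among the compounds named here.

Two compounds with a shared core, a methylpyrrolidine linked through an oxygen to a six-membered aromatic ring with one nitrogen, have been measured in an assay on membranes from brain for displacement of a labelled ligand from Neuronal acetylcholine receptor; alpha4/beta2 (Rattus norvegicus); a lower number here means a stronger inhibitor, a higher number a weaker inhibitor. Compound 1 `Cc1ncccc1OC[C@@H]1CCCN1C` gives 22.9 nM in this assay. Compound 2 `CN1CCC[C@H]1COc1cncc(C(F)(F)F)c1` gives 1.83 nM in this assay and so stands with the lowest of the two numbers, its nearest neighbour being compound 1 with a higher number, a gap that is beyond the usual scatter.

Compound 3 `CCNc1cncc(OC[C@@H]2CCCN2C)c1` has not yet been measured. It differs from compound 2 in one place: ethylamino in place of trifluoromethyl on an aromatic carbon. The group that enters carries a hydrogen-bond donor and a hydrogen-bond acceptor where the group that leaves carried none, and it sits two atoms from the ring nitrogen.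

For the measured compounds named here, no measured pair shows this kind of change, so the expectation rests on compound 2 alone. The step from compound 2 to compound 3 is expected to raise the number, by a 4.4-fold higher number from compound 2 to compound 3 (0.64 log units; beyond the scatter), a move beyond the scatter but not a large one. For compound 3 the estimate in this assay is 8 nM, with a range from 2 nM to 35 nM.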

Compound 3, inhibition constant: 3.7 nM
Compound 3: middle estimate off by 2.2-fold (0.33 log units), on the high side; the range from low to high includes it.
By their numbers in this assay, from the lowest: compound 2; then compound 3; then compound 1.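

In this assay, the position two atoms from the ring nitrogen accepts a quite different group at only a modest cost: the change goes a 2.0-fold higher number from compound 2 to compound 3 (0.31 log units; beyond the scatter) and so lies beyond the usual scatter, but it is a small step. Ethylamino brings a hydrogen-bond donor and a hydrogen-bond acceptor where trifluoromethyl had neither, and compound 3 still gives 3.7 nM in this assay, so a group without donors or acceptors is not required at this place for a low number. No measurement here bears on why the number rises on this change.

With one step at this position, the two parts of ethylamino cannot be told apart: the nitrogen with its hydrogen may matter, the two-carbon chain may matter, or both. A plain amine, a methylamino group or a longer chain such as propylamino on the same aromatic carbon would separate these parts, while a carboxylic acid there would test a very different kind of group.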